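A few compounds are considered here, and "the series" means these few. Any claim that something is new, unique, unknown or untested is made for them only; others in the source may bear on it.

Measured so far in an ADME assay on HepG2 2.2.15 cells (Homo sapiens) for cytotoxicity; on this read-out lower numbers stand for higher toxicity in this test and higher numbers for lower toxicity in this test:
compound 1 `O=C(CCCCC(=O)Nc1ncc(Cc2ccc(F)cc2)s1)Nc1ncc(Cc2ccc(F)cc2)s1` gives a limit, > 50000 nM.
compound 2 `O=C(Nc1ncc(C(Oc2ccc3cc(Br)ccc3c2)c2ccc(Cl)cc2)s1)c1cccs1` is recorded as "not toxic" (no number reported).
compound 3 `COc1ccc(Br)c(COC(c2ccccc2)c2cnc(NC(=O)c3cccs3)s2)c1` is recorded as "not toxic" (no number reported).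

Compound 2 therefore stands without a single number in this assay; its entry is only the verbal record "not toxic" (no number reported). Of the other two compounds, compound 1 sits at the limit of > 50000 nM in this assay, at which 1 of the 3 values shown sits. Compound 3 likewise carries only a verbal entry, "not toxic" (no number reported). Compound 4 `CC(C)(C)C(=O)Nc1ncc(C(Oc2ccc3cc(Br)ccc3c2)c2ccc(Cl)cc2)s1` is still unmeasured. It differs from compound 2 in one place: tert-butyl in place of thiophen-2-yl on a carbonyl carbon. Within the data shown here, with no measured step of this kind to draw on, any shift in this assay from compound 2 to compound 4 is expected to stay within the scatter. Compound 4 is accordingly estimated at 50000 nM, within a range from 20000 nM to 100000 nM.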

Compound 4, half-maximal cytotoxic concentration: "not toxic" (no number reported)
The entry for compound 4 holds no number, and the estimate cannot be compared.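

Compound 2 and compound 4 both carry only the verbal record "not toxic" in this assay, so no step can be read between them. The compounds shown leave open whether tert-butyl in place of thiophen-2-yl shifts the half-maximal cytotoxic concentration at all.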